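A Methylsulfanyl Group Grown Into a Benzylsulfanyl Group

The source may report more compounds than this note shows. Statements on the series, on what has been measured and on what is new or still open speak of the compounds shown alone.

Of the compounds shown here, three have so far been measured in a functional assay on CCRF-CEM cells (Homo sapiens) for cytotoxicity; on this read-out higher numbers stand for lower toxicity in this test and lower numbers for higher toxicity in this test. Compound 1, `Cc1ccc(Cc2ncn3c(S)ncnc23)cc1`, gives 32800 nM. Compound 2, `CSC1N=CNc2c(C)nc(C)n21`, gives 440000 nM. Compound 3, `CSC1NC(=O)n2cnc(CCCCCOCc3ccccc3)c2N1`, does not give a number at all: its result is the limit of the test, > 120000 nM. That places compound 3 at the least toxic edge of what the test could report, as one of the entries sitting at the limit of > 120000 nM in this assay, at which 1 of the 3 values shown sits.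

The untested compound 4, `Cc1ccc(CSC2NC(=O)n3cnc(CCCCCOCc4ccccc4)c3N2)cc1`, differs from compound 3 in a single place: 4-methylphenyl in place of hydrogen on a saturated chain carbon bound to a sulfur. For the measured compounds named here, no measured pair of compounds differs by exactly this change, so its effect cannot be read off directly. Compound 1 does carry a 4-methylbenzyl group and compound 2 a methylsulfanyl group, yet their cores also differ, so their two values show only where each of them sits and nothing about this step on its own.

The step from compound 3 to compound 4 is expected to be moderate and toward higher toxicity, an at least 1.7-fold lower number from compound 3 to compound 4 (0.23 log units; that floor lies within the scatter). Compound 4 is estimated at 70000 nM, with a plausible range from 20000 nM to 250000 nM, and a fair chance remains that the test again reports only a limit.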

Compound 4, half-maximal cytotoxic concentration: 343000 nM
The estimate for compound 4 lay 4.9-fold (0.69 log units) below the measured number; measured number above the stated range.
By their numbers in this assay, from the lowest: compound 1; then compounds 4 and 2 (each within the scatter of the next).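

In this assay compound 3 gives only a limit (> 120000 nM) and not a number, so the step from compound 3 to compound 4 cannot be read: (the limit of > 120000 nM in this assay, at which 1 of the 4 values shown sits). The compounds shown leave open in which direction, and how far, 4-methylphenyl in place of hydrogen on a saturated chain carbon bound to a sulfur moves this read-out.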